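The source may hold more compounds than are shown below. What is called first, only, known or untested is meant among the compounds shown, and "the series" means these compounds.

In a functional assay (Sus scrofa) with sulfonylurea receptors; K-ATP channels (Homo sapiens) as the target (a lower number here means that less compound is needed, a higher number that more compound is needed for the effect), compound 1 `CC(=O)Nc1c(C(O)(C(F)(F)F)C(F)(F)F)ccc2ccccc12` gives 95.5 nM, compound 2 `C/C=C/C(=O)Nc1c(C(O)(C(F)(F)F)C(F)(F)F)ccc2ccccc12` gives 49 nM and compound 3 `O=C(Nc1c(C(O)(C(F)(F)F)C(F)(F)F)ccc2ccccc12)C1CC1` gives 126 nM. Compound 2 holds the lowest of the three numbers, with a 1.9-fold lower number from compound 1 to compound 2 (0.29 log units; within the scatter) and a 2.6-fold higher number from compound 2 to compound 3 (0.41 log units; beyond the scatter), the latter a modest gap. Compound 4 `O=C(Nc1c(C(O)(C(F)(F)F)C(F)(F)F)ccc2ccccc12)c1cccc(Cl)c1` carries 3-chlorophenyl in place of prop-1-en-1-yl on a carbonyl carbon. For the measured compounds named here, the two measured steps at this carbonyl carbon, a 1.9-fold lower number from compound 1 to compound 2 (0.29 log units; within the scatter) and a 2.6-fold higher number from compound 2 to compound 3 (0.41 log units; beyond the scatter), were both small, and neither introduced an aromatic ring, so an aryl group here has no precedent in the set. For compound 4 the expected step is at most modest, more likely toward a higher number than a lower one, giving a 1.5-fold higher number from compound 2 to compound 4 (0.18 log units; within the scatter) as the estimated step. Compound 4 is therefore estimated at 75 nM, with a range from 20 nM to 280 nM.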

Compound 4, half-maximal effective concentration: 851 nM
Estimate against measurement, compound 4: 11-fold (1.05 log units) below; measured number outside the range, above it.
By their numbers in this assay, from the lowest: compounds 2, 1 and 3 (each within the scatter of the next, the first and the last beyond it); then compound 4.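

For the compounds shown here, at this carbonyl carbon in this assay, the earlier steps were small at most, while 3-chlorophenyl raises the number against all three smaller groups (a 17-fold higher number from compound 2 to compound 4 (1.24 log units; beyond the scatter); a 6.8-fold higher number from compound 3 to compound 4 (0.83 log units; beyond the scatter); an 8.9-fold higher number from compound 1 to compound 4 (0.95 log units; beyond the scatter)). The position is therefore not indifferent to the group placed on it. No measurement at hand accounts for this step. Phenyl without chlorine would separate the contribution of the ring from that of the chlorine. Cyclohexyl or a longer chain would test whether an aromatic ring is needed for the rise at all.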